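From hydroxy to chloro: an expected cytotoxicity step

This account rests on a few compounds, and the source may have more. Where it says the series, first, only, none or still open, it means among the compounds named here.

Two measured compounds anchor this account. Compound 1 `COc1ccc(C(=O)/C=C/c2cc3ccccc3[nH]c2=O)cc1` gives 45000 nM in an ADME assay on SK-MEL-5 cells (Homo sapiens) for cytotoxicity, read by sulforhodamine B assay, with a stated time of 24 h (on this read-out lower numbers stand for higher toxicity in this test and higher numbers for lower toxicity in this test), and compound 2 `O=C(/C=C/c1cc2ccccc2[nH]c1=O)c1ccc(O)cc1` gives 37300 nM in this assay. Among the compounds with values here, the single measured step, a 1.2-fold lower number from compound 1 to compound 2 (0.08 log units; within the scatter), moves nothing beyond the scatter. Within the data shown here, compound 2 thus holds the lowest of the two numbers, with compound 1 as its only neighbour at a gap within the scatter, so no order between the two can be claimed.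

Compound 3 `O=C(/C=C/c1cc2ccccc2[nH]c1=O)c1ccc(Cl)cc1` has not yet been measured. It differs from compound 2 by chloro in place of hydroxy on an aromatic carbon. Among the measured compounds shown here, no measured step involves this exchange; the only step available, a 1.2-fold lower number from compound 1 to compound 2 (0.08 log units; within the scatter), concerns a different group on a different atom and stayed within the scatter, so it gives little guidance. On that thin basis the expected step, a 1.2-fold lower number from compound 2 to compound 3 (0.09 log units; within the scatter), is small, perhaps toward a somewhat lower number in this assay, but not clearly beyond the scatter. Compound 3 is therefore estimated at 30000 nM in this assay, within a range from 12000 nM to 80000 nM.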

Compound 3, concentration lethal to 50% of the cells: > 100000 nM
Compound 3 was reported as a limit; the forecaster's own chance of this, stated with the estimate: 10%; at least 3.3-fold (0.52 log units) between middle value and limit.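

Within the data shown here, at this place, para to a large group on the six-membered aromatic ring of carbon only, the read-out in this assay now responds to the group that sits there, which the earlier pair could not show, since the only earlier step, a 1.2-fold lower number from compound 1 to compound 2 (0.08 log units; within the scatter), concerned a methyl on the oxygen. Chloro stands apart from both oxygen-bearing groups, with an at least 2.6-fold higher number from compound 2 to compound 3 (0.42 log units; beyond the scatter) and an at least 2.2-fold higher number from compound 1 to compound 3 (0.34 log units; beyond the scatter), so on this read-out the change points to lower toxicity in this test whether it starts from hydroxy or from methoxy. Compound 3 is reported only as a limit, so both steps give a minimum size and not a full one: the limit of > 100000 nM in this assay, at which 1 of the 3 values shown sits.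

From the compounds shown here alone, whether a fluoro, a methyl or an amine at this place would follow chloro, or stay with hydroxy and methoxy, remains open, so the shift cannot yet be tied to chloro itself or to the loss of an oxygen on the ring. Also open, going by these compounds, is how far the true value of compound 3 lies from its limit, and whether the same exchange would do the same on a core other than the one shared here.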